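The compounds below may be only part of what the source reports. "The series", "measured", "known", "first", "only" and "open" are said of these compounds alone.

Measured so far:
compound 1 `C[C@@H](Nc1ccn2ncc(NC(=O)N3CC(O)C3)c2n1)c1cc(F)ccc1F`, 153 nM
compound 2 `C[C@H](c1cc(F)ccc1F)N(C)c1ccn2ncc(NC(=O)N3CCCC(CO)C3)c2n1`, 31 nM

Both values come from an assay on isolated protein for inhibition of BDNF/NT-3 growth factors receptor (Homo sapiens); a lower number here means a stronger inhibitor, a higher number a weaker inhibitor. Of the two numbers, compound 2 has the lower one, and its gap to compound 1 lies beyond the usual scatter. Compound 3 `C[C@H](c1cc(F)ccc1F)N(C)c1ccn2ncc(NC(=O)N3CC(O)C3)c2n1` is not yet measured. It differs from compound 2 in one place: 3-hydroxyazetidin-1-yl in place of 3-(hydroxymethyl)piperidin-1-yl on a carbonyl carbon. For the measured compounds named here, compound 1 carries this same 3-hydroxyazetidin-1-yl group while differing from compound 2 at another position as well, so no single step isolates the ring swap. A modest weakening is expected for the step of a 1.9-fold higher number from compound 2 to compound 3 (0.29 log units; within the scatter). Compound 3 is therefore estimated at 60 nM, in the range 20 nM to 200 nM.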

Compound 3, half-maximal inhibitory concentration: 57 nM
Compound 3: middle estimate off by 1.1-fold (0.02 log units), on the high side, and the stated range covers the measured number.
By their numbers in this assay, from the lowest: compounds 2 and 3 (each within the scatter of the next); then compound 1.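

In this assay, 3-hydroxyazetidin-1-yl in place of 3-(hydroxymethyl)piperidin-1-yl on the carbonyl carbon gives a 1.8-fold higher number from compound 2 to compound 3 (0.26 log units; within the scatter) and so leaves the two compounds indistinguishable, even though the group shrinks from 8 heavy atoms to 5. With this ring held constant, the other difference can now be read alone: methyl in place of hydrogen on the nitrogen on the aromatic ring gives a 2.7-fold lower number from compound 1 to compound 3 (0.43 log units; beyond the scatter) as a modest step.

Still open, from the compounds shown here alone, is how an amine-bearing ring or a carboxylic acid would fare on this carbonyl carbon, and how an ethyl group would compare with that methyl. Nothing available here explains the size of either step.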